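The compounds below may be only part of what the source reports. "The series", "measured", "known", "first", "only" and "open" are said of these compounds alone.

Measured in an ADME assay on microsomes from liver (Homo sapiens), read by LC-MS, using NADPH, with a stated time of 30 min, tested at 1 uM; on this read-out lower numbers stand for a less stable compound and higher numbers for a more stable compound:

compound 1 `C[C@H](Nc1nc(N)nc(N)c1C#N)c1cc2ccc(F)cn2c(=O)c1-c1ccccc1` — 87%
compound 2 `Cc1nc(N)nc(N[C@@H](C)c2cc3ccc(F)cn3c(=O)c2-c2ccccc2)c1C#N` — 83%
compound 3 `C[C@H](Nc1nc(N)nc(N)c1C#N)c1cc2ccc(F)cn2c(=O)c1-c1ccc(F)cc1` — 87%

Compound 1 stands level with compound 3 at the digits given, the two together the highest of the three numbers; the nearest step is no change at the digits printed from compound 1 to compound 3 (within the scatter), the furthest is a number 4 percentage points lower from compound 1 to compound 2 (within the scatter), both within the scatter.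

Compound 4 `C[C@H](Nc1nc(N)nc(N)c1C#N)c1c(-c2ccccc2)c(=O)n2cc(F)ccc2c1C1CC1` is unmeasured. Against compound 1 the change is cyclopropyl in place of hydrogen on an aromatic carbon. For the measured compounds named here, neither measured step concerns a cyclopropyl entering; the two steps at hand, a number 4 percentage points lower from compound 1 to compound 2 (within the scatter) and no change at the digits printed from compound 1 to compound 3 (within the scatter), stayed within the scatter, so the series so far gives no ground for a step beyond the scatter in this assay, though a carbon ring entering is a larger change than either.

Compound 4 is therefore expected near 80%, range 60% to 93%, that is an expected step of a number 7 percentage points lower from compound 1 to compound 4 (within the scatter).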

Compound 4, percent of the compound remaining: 91%
The estimate for compound 4 lay 11 percentage points below the measured number; measured number inside the range.
By their numbers in this assay, from the lowest: compounds 2, 1, 3 and 4 (each within the scatter of the next).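

On the aromatic carbon ortho to a fused ring, cyclopropyl in place of hydrogen gives a number 4 percentage points higher from compound 1 to compound 4 (within the scatter) in this assay. The earlier steps shown here changed only a single atom or swapped one small group for another, whereas this one adds a three-membered carbon ring at a new position and still stays within the scatter. No available data explain this result.

Open, as far as these compounds go, is whether an amine or a longer alkyl chain on this same carbon would also stay within the scatter. Also open, from the compounds shown here alone, is whether cyclopropyl gives the same step alongside the other changes.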